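The source may hold more compounds than are shown below. What is called first, only, known or untested is meant among the compounds shown, and "the series" means these compounds.

Measured so far:
Compound 1 `O=C(CN1CCN(C(=O)c2ccccc2)CC1)N1CCN(CCCc2c[nH]c3ccccc23)CC1`: > 200000 nM (a limit of the assay, not a number)
Compound 2 `O=C(CN1CCN(C(=O)c2ccccc2)CC1)N1CCN(CCCc2c[nH]c3ccc(F)cc23)CC1`: 146000 nM

Both entries come from an ADME assay on SH-SY5Y cells (Homo sapiens) for cytotoxicity, read by MTT assay, with a stated time of 72 h; on this read-out lower numbers stand for stronger inhibition and higher numbers for weaker inhibition. Within the data shown here, compound 2 gives the only true number, 146000 nM, so it cannot be ranked against another number.

Compound 3 `COc1ccc2[nH]cc(CCCN3CCN(C(=O)CN4CCN(C(=O)c5ccccc5)CC4)CC3)c2c1` carries methoxy in place of fluoro on an aromatic carbon, the swap from 5-fluoro-1H-indol-3-yl to 5-methoxy-1H-indol-3-yl (methoxy in place of fluoro on an aromatic carbon). Among the measured compounds shown here, the one measured step that bears on this is an at least 1.3-fold lower number from compound 1 to compound 2 (0.13 log units; that floor lies within the scatter), the step that brings in the fluoro group. No data yet cover methoxy on this core. Given that small step, no change beyond the scatter is expected in either direction, and the expected step is a 1.0-fold lower number from compound 2 to compound 3 (0.02 log units; within the scatter). A report of compound 3 only as a limit would not be unexpected. Compound 3 is estimated at 140000 nM, with an expected range of 60000 nM to 200000 nM.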

Compound 3, half-maximal inhibitory concentration: > 200000 nM
Compound 3: no number, only a limit (the forecaster's own chance of this, stated with the estimate: 35%); at least 1.4-fold (0.15 log units) between middle value and limit.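

In this assay, methoxy in place of fluoro on this aromatic carbon gives an at least 1.3-fold higher number from compound 2 to compound 3 (0.13 log units; that floor lies within the scatter). Compound 3 gives > 200000 nM, a limit of the assay and not a number, so this position now carries a second substituent, one with a hydrogen-bond acceptor, and only the fluoro compound has a true number. The step from compound 1 to compound 3 cannot be read, and the change from compound 2 has only a floor, because the values run into the limit of the read-out: the limit of > 200000 nM in this assay, at which 2 of the 3 values shown sit.

Going by these compounds, whether methoxy differs from fluoro or hydrogen on this carbon beyond the scatter stays open. Also open, on these data alone, is whether an amine, a carboxylic acid or a longer chain at this place would give a true number in this assay.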